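The source may report more compounds than this note shows. Statements on the series, on what has been measured and on what is new or still open speak of the compounds shown alone.

Measured compounds in a functional assay on cells for antagonist activity at C-C chemokine receptor type 4 (Homo sapiens), read by GTPgammaS binding; on this read-out higher numbers stand for weaker inhibition and lower numbers for stronger inhibition:
- compound 1, `COc1nn(C2COC2)c2ncnc(NS(=O)(=O)c3cccc(Cl)c3Cl)c12`: 251 nM
- compound 2, `COc1nc(NS(=O)(=O)c2cccc(Cl)c2Cl)c2c(OC)nn(C)c2n1`: 794 nM

Of the two compounds measured in this assay, compound 2 stands at the higher number. Its nearest neighbour is compound 1, whose number is lower by a margin that lies beyond the usual scatter of repeated measurements, so the two compounds do differ on this read-out.

Compound 3, `CCNc1nc(NS(=O)(=O)c2cccc(Cl)c2Cl)c2c(OC)nn(C)c2n1`, is reached from compound 2 by one change: ethylamino in place of methoxy on an aromatic carbon. Among the compounds with values here, no pair of measured compounds shows this exchange, so there is no measured step to lean on. Within the data shown here, the only guidance is the spread of the two measured numbers, which covers a moderate range. On that basis, the step from compound 2 to compound 3 in this assay is expected to be small, most likely within the scatter, with no clear direction favoured.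

Compound 3 is therefore expected to give about 600 nM in this assay, within a range from 150 nM to 2500 nM. The expected change amounts to a 1.3-fold lower number from compound 2 to compound 3 (0.12 log units; within the scatter).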

Compound 3, half-maximal inhibitory concentration: 251 nM
Compound 3: middle estimate off by 2.4-fold (0.38 log units), on the high side, within the range that was stated.
By their numbers in this assay, from the lowest: compounds 1 and 3 (each within the scatter of the next); then compound 2.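

In this assay, within the data shown here, the exchange of methoxy for ethylamino on this aromatic carbon, placed between two ring nitrogen atoms, comes with a 3.2-fold lower number from compound 2 to compound 3 (0.50 log units; beyond the scatter), the first measured step at this position and one that shows the number here responds to the group it carries. Ethylamino brings 1 hydrogen-bond donor where methoxy has 0, and 3 heavy atoms where methoxy has 2, with nitrogen in place of oxygen, so this single step cannot separate these differences from one another. No accompanying measurement bears on what lies behind the step.

The compounds shown leave open whether methylamino, dimethylamino, which has no amine hydrogen, or a longer chain such as propylamino would take the number further in the same direction or reverse it at this position. They also leave open whether ethylamino would bring a step of similar size on the core of compound 1.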